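The compounds below may be only part of what the source reports. "The series", "measured", "known", "first", "only" and "open" are said of these compounds alone.

In a functional assay on HeLa cells (Homo sapiens) for inhibition, read by MTT assay, with a stated time of 24 h (a higher number here means a weaker inhibitor, a lower number a stronger inhibitor), compound 1 `CCOC1c2cc(OCc3cc(C)cc(C)c3)c(OCc3cc(C)cc(C)c3)cc2CCN1C(=O)OC(C)(C)C` gives > 20000 nM, which is a limit of the assay and not a number. Compound 2 `CC[C@@H]1C[C@H](O)C/C=C(/C)[C@H]2c3cc(OCc4ccccc4)c(OCc4ccccc4)cc3CCN12` gives > 20000 nM, again a limit. Compound 3 `CC[C@@H]1CC(=O)C/C=C(/C)[C@H]2c3cc(OCc4ccccc4)c(OCc4ccccc4)cc3CCN12` gives > 20000 nM, also a limit. Compound 1 therefore stands with the other two at the limit of > 20000 nM in this assay, at which 3 of the 3 values shown sit, and no measured number sets its place any more exactly.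

Compound 4 `Cc1cc(C)cc(COc2cc3c(cc2OCc2cc(C)cc(C)c2)CN(C(=O)OC(C)(C)C)CC3)c1` departs from compound 1 in one place: hydrogen in place of ethoxy on a saturated ring carbon, with hydrogen in place of ethoxy on a saturated ring carbon. Within the data shown here, no two measured compounds differ in one place only, so the data offer no direct guide to the size of this change. The expectation rests on compound 1 at > 20000 nM, itself only a limit, and no shift beyond the scatter is foreseen in this assay. The estimated result is a number no higher from compound 1 to compound 4 (the limit leaves the size open), and the assay may well again report only a limit. For compound 4 the expected value is 20000 nM, with an estimated range of 8000 nM to 40000 nM.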

Compound 4, half-maximal inhibitory concentration: > 20000 nM
Compound 4 gave a limit, no number; the forecaster's own chance of this, stated with the estimate: 75%; the middle value lies on the limit itself.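

Compound 1 and compound 4 each give only a limit of the assay and not a number, so the step between them cannot be read: the limit of > 20000 nM in this assay, at which 4 of the 4 values shown sit.

The compounds shown leave open what size of effect, if any, hydrogen in place of ethoxy has in this assay.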